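Trading the aromatic ring for a propyl chain

The source may hold more compounds than are shown below. What is called first, only, known or untested is meant among the compounds shown, and "the series" means these compounds.

Compound 3 `CN1CCC[C@@H]1Cn1nc(CCc2ccccc2)c2ccccc2c1=O` carries a phenethyl side chain on the shared core. In an assay for binding affinity to Alpha-1A adrenergic receptor (Homo sapiens) (on this read-out lower numbers stand for stronger inhibition and higher numbers for weaker inhibition), compound 3 gives 200 nM, the lower of the two numbers among the three compounds measured, though its gap to compound 1 is within the scatter. Compound 1 `CN1CCC[C@@H]1Cn1nc(Cc2ccc(O)cc2)c2ccccc2c1=O`, with a 4-hydroxyphenyl in that place, gives 251 nM. The step of a 1.3-fold lower number from compound 1 to compound 3 (0.10 log units; within the scatter) is within the scatter. Compound 2 `CN1CCC[C@@H]1Cn1nc(CC2CCCCC2)c2ccccc2c1=O` carries a cyclohexyl there. For compound 2 the assay reports only a limit, > 1990 nM; this is the limit of > 1990 nM in this assay, at which 1 of the 3 values shown sits.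

Compound 4 `CCCCCc1nn(C[C@H]2CCCN2C)c(=O)c2ccccc12` is the next compound to be measured. Its change from compound 3 is propyl in place of phenyl on a saturated chain carbon, two bonds along the chain from an aromatic carbon, so the aromatic ring of the side chain leaves and a straight chain remains. For the measured compounds named here, two measured steps bear on this: an at least 7.9-fold higher number from compound 1 to compound 2 (0.89 log units; beyond the scatter) and an at least 9.9-fold lower number from compound 2 to compound 3 (0.99 log units; beyond the scatter). Both place the compound with the saturated cyclohexyl at a higher number, beyond the scatter, than its aromatic counterparts. Since the change to compound 4 also removes the aromatic ring, a step upward of similar size is expected, a 10-fold higher number from compound 3 to compound 4 (1.00 log units; beyond the scatter). Compound 4 is therefore expected to give about 2000 nM in this assay, between 500 nM and 8000 nM, with a fair chance that only a limit is reported.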

Compound 4, inhibition constant: 501 nM
Beside the measured number, compound 4's estimate is 4.0-fold (0.60 log units) above it; the measured number falls inside the stated range.
By their numbers in this assay, from the lowest: compounds 3, 1 and 4 (each within the scatter of the next, the first and the last beyond it). At a limit, above all of these: compound 2.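

In this assay, the phenyl of the side chain can be given up at a far smaller cost than the cyclohexyl compound suggested: propyl in its place gives a 2.5-fold higher number from compound 3 to compound 4 (0.40 log units; beyond the scatter). Set against the 4-hydroxyphenyl side chain, the same straight chain gives a 2.0-fold higher number from compound 1 to compound 4 (0.30 log units; within the scatter), so among these compounds an aromatic ring in the side chain is not required for a number of this order. A saturated side chain alone therefore does not go with the loss seen for compound 2, whose result is only a limit, which makes an at least 3.9-fold lower number from compound 2 to compound 4 (0.59 log units; beyond the scatter) a bound and not a measured size: the limit of > 1990 nM in this assay, at which 1 of the 4 values shown sits.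

The compounds shown leave open how the number follows chain length, as the pentyl chain of compound 4 is the only straight chain among them, and a longer chain such as heptyl or a shorter one such as ethyl would show whether it sits at a favourable length. They also leave open whether a group at the end of that chain, such as an amine or a hydroxyl, would move the number in either direction.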